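Pentyl in place of hydrogen on compound 2's aromatic carbon

The source may report more compounds than this note shows. Statements on the series, on what has been measured and on what is new or still open speak of the compounds shown alone.

Measured so far in an assay on FRT-Jurkat cells for inhibition of nuclear factor NF-kappa-B complex (Homo sapiens), read by flow cytometry, with a stated time of 24 h, tested at 10 uM; on this read-out higher numbers stand for more inhibition at the one concentration tested (going by the name of the read-out) and lower numbers for less inhibition:
compound 1 `O=C1CCC(N2C(=O)c3ccc(Nc4ccccc4)cc3C2=O)C(=O)N1` gives 6%
compound 2 `O=C1CCC(N2C(=O)c3cccc(Nc4ccccc4)c3C2=O)C(=O)N1` gives 4%
compound 3 `O=C1CCC(N2C(=O)c3ccc(Nc4ccc(O)cc4)cc3C2=O)C(=O)N1` gives 4%

All three numbers sit close together. Compound 2 stands level with compound 3 at the digits printed, the two of them together the lowest of the three, and compound 1 is only a little higher; these gaps are within the scatter, so no order among the three can be read from them.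

One measured step changes a single place: from compound 1 to compound 3, a number 2 percentage points lower from compound 1 to compound 3 (within the scatter), with hydroxy in place of hydrogen on an aromatic carbon. That step is within the scatter.

Compound 4 `CCCCCc1ccc(Nc2cccc3c2C(=O)N(C2CCC(=O)NC2=O)C3=O)cc1` differs from compound 2 by pentyl in place of hydrogen on an aromatic carbon. Among the measured compounds shown here, no measured step puts a chain onto this ring, so the only guide is that the one substitution on this ring, from compound 1 to compound 3, left the read-out essentially unchanged, and that every compound so far sits at the low end of the scale. On that basis a step of about a number 2 percentage points higher from compound 2 to compound 4 (within the scatter) is expected, no clear direction beyond the scatter. Compound 4 is estimated at 6%, with a range from -4% to 18%.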

Compound 4, a percentage reported as inhibition, at one concentration (the size of the read-out at that concentration, not a potency): 23%
Compound 4: the middle estimate sits 17 percentage points below what was measured; the whole stated range lies below it.
By their numbers in this assay, from the lowest: compounds 2, 3 and 1 (each within the scatter of the next); then compound 4.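

In this assay, pentyl on the aromatic carbon para to a large group gives a number 19 percentage points higher from compound 2 to compound 4 (beyond the scatter), so this position on the outer six-membered aromatic ring of carbon only can move the read-out, a change of modest size. It is the only step shown that lies beyond the scatter: the one earlier step, a number 2 percentage points lower from compound 1 to compound 3 (within the scatter), placed hydroxy on the same kind of ring and, being within the scatter, showed no change that could be read. Nothing available bears on why pentyl changes the read-out, so the step stands as an observation without an explanation.

The compounds shown leave open whether the step follows chain length, as a propyl or octyl chain in the same place would show, and whether a chain ending in an amine or a carboxylic acid behaves like pentyl. As far as these compounds go, it also remains open whether pentyl gives a comparable step on the core of compound 1, and, with one concentration tested, how potent compound 4 is.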